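The source may hold more compounds than are shown below. What is called first, only, known or untested is meant among the compounds shown, and "the series" means these compounds.

Measured so far:
- compound 1 `C[C@H]1Cn2ncc(N3CC(c4ccccc4)CC3=O)c2CN1C(=O)NCc1cc(F)c(F)c(F)c1`: > 2000 nM
- compound 2 `Cc1cnc(C2CC(=O)N(c3cnn4c3CN(C(=O)Nc3cc(F)c(F)c(F)c3)C(C3CC3)C4)C2)s1`: 96200 nM

Among the compounds with values here, in a toxicity assay on HepG2 2.2.15 cells (Homo sapiens) for cytotoxicity, read by CellTiter-Glo (on this read-out lower numbers stand for higher toxicity in this test and higher numbers for lower toxicity in this test), compound 2 gives 96200 nM, the only number. For compound 1 the result > 2000 nM is a limit of the assay, not a number. Evidence on this point: the limit of > 2000 nM in this assay, at which 1 of the 2 values shown sits. Nothing in the series sets a measured step between two compounds.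

Compound 3 `Cc1nc(C2CC(=O)N(c3cnn4c3CN(C(=O)Nc3cc(F)c(F)c(F)c3)C(C3CC3)C4)C2)no1` differs from compound 2 in one place: 5-methyl-1,2,4-oxadiazol-3-yl in place of 5-methyl-1,3-thiazol-2-yl on a saturated ring carbon. Within the data shown here, no measured pair sizes such a change; the step of a 1.1-fold lower number from compound 2 to compound 3 (0.03 log units; within the scatter) is expected to stay within the scatter, in no clear direction. Compound 3 is therefore estimated at 90000 nM, with a range of 40000 nM to 200000 nM.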

Compound 3, half-maximal cytotoxic concentration: > 200000 nM
Compound 3: only a limit was reported; the forecaster's own chance of this, stated with the estimate: 25%; middle value at least 2.2-fold (0.34 log units) away from the limit.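

For compound 3, > 200000 nM is a limit of the assay, not a number. In this assay, 5-methyl-1,2,4-oxadiazol-3-yl in place of 5-methyl-1,3-thiazol-2-yl gives an at least 2.0-fold higher number from compound 2 to compound 3 (0.31 log units; beyond the scatter). This first measured pair shows that swapping one five-membered aromatic ring for another on this saturated ring carbon can move the read-out beyond the scatter, towards lower toxicity in this test.

Going by these compounds, the full size of the step stays open, since only a limit bounds it. Also open, on these data alone, is how an amine or a carboxylic acid on this carbon would read, and one pair sets no trend.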